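This account rests on a few compounds, and the source may have more. Where it says the series, first, only, none or still open, it means among the compounds named here.

Of the compounds shown here, two have so far been measured in a functional assay on RPMI-8226 cells (Homo sapiens) for inhibition, read by sulforhodamine B assay, with a stated time of 48 h, tested at 100 uM; on this read-out higher numbers stand for a weaker effect at the one concentration tested and lower numbers for a stronger effect. Compound 1 `COc1cc(Cl)cc(-c2nn(-c3cccc(NC(=O)Nc4ccc(Cl)c(C(F)(F)F)c4)c3)cc2-c2ccncc2)c1` gives -32% in this assay. Compound 2 `COc1cc(Cl)cc(-c2nn(-c3cccc(NC(=O)Nc4cccc(C(F)(F)F)c4)c3)cc2-c2ccncc2)c1` gives -43% in this assay. Among the compounds with values here, these two differ only in hydrogen in place of chloro on an aromatic carbon, and the resulting step, a number 11 percentage points lower from compound 1 to compound 2 (beyond the scatter), is the only measured step available. Within the data shown here, on these numbers compound 2 stands lowest of the two, with compound 1 as its sole neighbour, and the gap between them lies beyond the scatter.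

Compound 3 `COc1cc(Cl)cc(-c2nn(-c3cccc(NC(=O)c4cccc(C(F)(F)F)c4)c3)cc2-c2ccncc2)c1` has not yet been measured. It differs from compound 2 by 3-(trifluoromethyl)phenyl in place of (3-(trifluoromethyl)phenyl)amino on a carbonyl carbon. Among the measured compounds shown here, no measured step touches this part of the molecule; the one known step, between compound 1 and compound 2, alters a different group and is modest, so it bears only loosely on what to expect here. With nothing pointing clearly in either direction, no step beyond the scatter is expected, and the expected step is a number 5 percentage points higher from compound 2 to compound 3 (within the scatter). Compound 3 is therefore estimated at -38% in this assay, with a range from -62% to -14%.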

Compound 3, a percentage reported as activity, at one concentration (the size of the read-out at that concentration, not a potency): 22%
Beside the measured number, compound 3's estimate is 60 percentage points below it; measured number above the stated range.
By their numbers in this assay, from the lowest: compound 2; then compound 1; then compound 3.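

In this assay, the group on the carbonyl carbon matters far more than the chloro change seen earlier, which gave only a number 11 percentage points lower from compound 1 to compound 2 (beyond the scatter). Putting 3-(trifluoromethyl)phenyl in place of (3-(trifluoromethyl)phenyl)amino, so that the amino nitrogen and its hydrogen are lost, gives a number 65 percentage points higher from compound 2 to compound 3 (beyond the scatter), and the comparison with the chloro-bearing (4-chloro-3-(trifluoromethyl)phenyl)amino group points the same way, with a number 54 percentage points higher from compound 1 to compound 3 (beyond the scatter), so both compounds that keep the amino nitrogen read below zero while compound 3 reads 22%. No measurement on hand explains why this change has such a large effect.

The compounds shown cannot separate the loss of the nitrogen from the loss of its hydrogen, a question that an N-methylamino group in the same place, or a methylene or an ether oxygen in place of the amino nitrogen, would help to settle. On these data alone, it also remains open whether a chloro on the ring of compound 3 would shift the read-out as it does among the compounds that keep the amino nitrogen.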